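A few compounds are considered here, and "the series" means these few. Any claim that something is new, unique, unknown or untested is made for them only; others in the source may bear on it.

Measured so far:
- compound 1, `Nc1ccc2sc(NC(=S)NC(=O)c3ccc([N+](=O)[O-])cc3)nc2c1`: 33200 nM
- compound 2, `O=C(NC(=S)Nc1nc2cc(Br)ccc2s1)N1CCOCC1`: 18100 nM
- compound 3, `CCCCC(=O)NC(=S)Nc1nc2ccccc2s1`: 36600 nM

Three acylthiourea derivatives of a shared benzothiazole-type core have been tested in a functional assay on MCF7 cells (Homo sapiens) for cytotoxicity, read by MTT assay, with a stated time of 24 h; a higher number here means a weaker inhibitor, a lower number a stronger inhibitor. In this assay compound 1 gives 33200 nM, compound 3 gives 36600 nM and compound 2 gives 18100 nM. The number for compound 1 sits between the other two, and its gap to each of them is within the usual scatter of this assay, so the three measurements cannot be told apart with confidence.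

The next compound, compound 4, `O=C(NC(=S)Nc1nc2cc([N+](=O)[O-])ccc2s1)c1ccc([N+](=O)[O-])cc1`, has not been measured. It differs from compound 1 in one place: nitro in place of amino on an aromatic carbon. Among the measured compounds shown here, no measured pair in this set shows what such a change does, so the expectation rests only on the spread already seen among compound 1, compound 2 and compound 3, which is narrow. Compound 4 is therefore expected to stay near compound 1, with a step of a 1.2-fold lower number from compound 1 to compound 4 (0.07 log units; within the scatter) that is not expected to go beyond the scatter in either direction. The estimate for compound 4 in this assay is 28000 nM, within a range from 9000 nM to 90000 nM.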

Compound 4, half-maximal inhibitory concentration: 35200 nM
Compound 4: middle estimate off by 1.3-fold (0.10 log units), on the low side; the measured number falls inside the stated range.
By their numbers in this assay, from the lowest: compounds 2, 1, 4 and 3 (each within the scatter of the next, the first and the last beyond it).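

In this assay the exchange of amino for nitro on this aromatic carbon of the fused ring system gives a 1.1-fold higher number from compound 1 to compound 4 (0.03 log units; within the scatter), so this single change leaves no readable difference. The earlier compounds shown here offered no pair that tested this position, and here three heavy atoms replace one and the amino group's hydrogen-bond donor is lost with no shift beyond the scatter. Nothing available explains why the number holds.

Going by these compounds, it remains open whether a carboxylic acid, a methoxy group or a dimethylamino group on the same carbon would also stay within the scatter of compound 1. On these data alone, it is also open whether the exchange of amino for nitro would read the same with a pentanoyl or morpholine-4-carbonyl group in place of the 4-nitrobenzoyl group of compound 1.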